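The source may hold more compounds than are shown below. What is called first, only, known or untested is meant among the compounds shown, and "the series" means these compounds.

Compound 1 `O=C(O)C1=CO[C@@H](O[C@@H]2O[C@H](COCc3ccccc3)[C@@H](OCc3ccccc3)[C@H](OCc3ccccc3)[C@H]2OCc2ccccc2)[C@@H]2C(COCc3ccccc3)=CC[C@H]12`: > 200000 nM
Compound 2 `O=C(Nc1ccc(Oc2ccccc2)cc1)C1=CO[C@@H](O[C@@H]2O[C@H](COCc3ccccc3)[C@@H](OCc3ccccc3)[C@H](OCc3ccccc3)[C@H]2OCc2ccccc2)[C@@H]2C(COCc3ccccc3)=CC[C@H]12`: > 200000 nM
Compound 3 `CCOS(=O)(=O)/C=C/c1ccc(OCC2=CC[C@@H]3C(C(=O)Nc4ccc(Oc5ccc(-c6ccccc6)cc5)cc4)=CO[C@@H](OC)[C@H]23)cc1`: > 200000 nM

These results come from an ADME assay on HepG2 cells (Homo sapiens) for cytotoxicity, read by MTT assay, with a stated time of 24 h (a higher number here means a weaker inhibitor, a lower number a stronger inhibitor), and each is a limit of the assay, not a number. Compound 3 gives only the limit > 200000 nM. All the compounds tested share (the limit of > 200000 nM in this assay, at which 3 of the 3 values shown sit).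

Compound 4 `CCOS(=O)(=O)/C=C/c1ccc(OCC2=CC[C@@H]3C(C(=O)Nc4ccc(Oc5ccc6ccccc6c5)cc4)=CO[C@@H](OC)[C@H]23)cc1` differs from compound 3 in one group: naphthalen-2-yl in place of 4-phenylphenyl on an oxygen on an aromatic ring. Among the measured compounds shown here, no two measured compounds differ in only one place, which leaves no measured step as a guide. With only the limit > 200000 nM for compound 3, no step beyond the scatter, in either direction, is expected in this assay. The expected step of a number no higher from compound 3 to compound 4 (the limit leaves the size open) is therefore small. Compound 4 is estimated at 200000 nM, with an expected range of 100000 nM to 300000 nM.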

Compound 4, half-maximal inhibitory concentration: > 200000 nM
Compound 4 was reported as a limit (the forecaster's own chance of this, stated with the estimate: 85%); the middle value lies on the limit itself.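

Among the compounds shown here, compound 3 and compound 4 are both reported only as limits, and no step between them can be read in this assay. The compounds shown leave open the concentration at which any of them would reach half-maximal inhibition.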